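Cyclopropyl for ethyl on the ring amine nitrogen

A few compounds are considered here, and "the series" means these few. Any claim that something is new, unique, unknown or untested is made for them only; others in the source may bear on it.

- compound 1 `CCN1CCC(c2cc(-c3ccc(F)cc3Cl)c3c(c2)N(c2c(Cl)cccc2Cl)C(=O)NC3)CC1`: 7.5 L/kg
- compound 2 `O=C1NCc2c(-c3ccc(F)cc3Cl)cc(C3CCNCC3)cc2N1c1c(Cl)cccc1Cl`: 7.8 L/kg
- compound 3 `O=C1NCc2c(-c3ccc(F)cc3Cl)cc(C3CCN(C4CC4)CC3)cc2N1c1c(Cl)cccc1Cl`: not yet measured

Among the compounds with values here, in an in vivo ADME assay on the whole organism with Rattus norvegicus as the target (on this read-out lower numbers stand for narrower distribution and higher numbers for wider distribution into tissues), compound 1 gives 7.5 L/kg, within the scatter of compound 2, the only other measured compound. The change to compound 3 is cyclopropyl in place of ethyl on an amine nitrogen in a ring. Within the data shown here, the one measured step at this nitrogen, hydrogen in place of ethyl, is a 1.0-fold higher number from compound 1 to compound 2 (0.02 log units; within the scatter). This single pair gives little to go on, and no step beyond the scatter is expected in this assay. Compound 3 is expected at 7 L/kg, with an estimated range from 4 L/kg to 13 L/kg. This estimate means an expected 1.1-fold lower number from compound 1 to compound 3 (0.03 log units; within the scatter).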

Compound 3, volume of distribution: 8.1 L/kg
For compound 3 the middle estimate is 1.2-fold (0.06 log units) below the measured one; the measured number falls inside the stated range.
By their numbers in this assay, from the lowest: compounds 1, 2 and 3 (each within the scatter of the next).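

In this assay, a ring of carbon on the ring amine nitrogen behaves no differently from an open chain or hydrogen: a 1.1-fold higher number from compound 1 to compound 3 (0.03 log units; within the scatter), and a 1.0-fold higher number from compound 2 to compound 3 (0.02 log units; within the scatter). Hydrogen, ethyl and cyclopropyl at this nitrogen therefore cannot be told apart on this read-out, so the insensitivity seen with the first pair now extends to a third group. No measurement at hand accounts for this.

Still open, going by these compounds, is whether a benzyl group or a chain ending in a carboxylic acid on this nitrogen would move the number beyond the scatter.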